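The source may hold more compounds than are shown below. What is called first, only, known or untested is meant among the compounds shown, and "the series" means these compounds.

Of the compounds shown here, two have been measured for cytotoxicity. In a functional assay on HepG2 cells (Homo sapiens) for cytotoxicity, read by MTT assay, with a stated time of 48 h (on this read-out lower numbers stand for stronger inhibition and higher numbers for weaker inhibition), compound 1, `CCC(=O)N1N=C(C)CC1c1cc(Br)cc(Br)c1O`, gives 41400 nM. Compound 2, `O=C(c1ccccc1)N1N=C(c2cc3ccccc3oc2=O)CC1c1ccccc1`, gives 36600 nM in this assay, the lower of the two numbers, though compound 1 sits only a step within the usual scatter away, so the two cannot be ranked against each other.

Compound 3, `Cc1ccc(S(=O)(=O)N2N=C(c3cc4ccccc4oc3=O)CC2c2ccccc2)cc1`, has not yet been measured. It differs from compound 2 in one place: (4-methylphenyl)sulfonyl in place of benzoyl on an amine nitrogen in a ring. Among the compounds with values here, no measured pair shows a change of this kind, so nothing in the data tells how such a swap shifts the number. With both measured values so close together, the expectation for compound 3 is a number near that of compound 2, with the step from compound 2 to compound 3 estimated at a 1.0-fold lower number from compound 2 to compound 3 (0.02 log units; within the scatter), which lies within the scatter. Compound 3 is therefore expected to give about 35000 nM in this assay, most likely between 12000 nM and 100000 nM.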

Compound 3, half-maximal inhibitory concentration: "not active" (no number reported)
No number was reported for compound 3, so the estimate cannot be set against anything.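

Within the data shown here, compound 3 is reported in this assay only as "not active", without a number, so no step from compound 2 to compound 3 can be read. How (4-methylphenyl)sulfonyl in place of benzoyl shifts the number stays open, and the data shown offer no explanation for this result.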